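The source may report more compounds than this note shows. Statements on the series, on what has been measured and on what is new or still open speak of the compounds shown alone.

Measured compounds:
compound 1, `CC1CC/C(=N\Nc2ccccc2F)c2ncc(C(=O)O)c(=O)n21`, > 1000 umol/kg
compound 2, `CC1CC/C(=N\Nc2ccccc2[N+](=O)[O-])c2ncc(C(=O)O)c(=O)n21`, > 1000 umol/kg

In a functional assay on the whole organism for inhibition, with Rattus norvegicus as the target (on this read-out higher numbers stand for an effect only at larger amounts of compound and lower numbers for an effect already at smaller amounts), compound 1 gives > 1000 umol/kg, which is a limit of the assay and not a number. In this assay compound 2 gives > 1000 umol/kg, likewise a limit of the assay. Among the compounds with values here, the one step within the measured pair, a step that the two limits leave unreadable from compound 1 to compound 2, is unreadable because the limit of > 1000 umol/kg in this assay, at which 2 of the 2 values shown sit, holds both values. Compound 2 therefore stands at the limit of this assay with no numerical value, and no ordering between the two measured compounds can be stated.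

Compound 3, `CC1CC/C(=N\Nc2ccccc2CCO)c2ncc(C(=O)O)c(=O)n21`, differs from compound 2 by 2-hydroxyethyl in place of nitro on an aromatic carbon. Within the data shown here, no measured step bears on this change: the only step in the set is unreadable, so neither a direction nor a size can be drawn from it. The expectation rests on where compound 2 stands, at > 1000 umol/kg, a limit. Compound 3 is expected at 1500 umol/kg, with a range from 500 umol/kg to 5000 umol/kg. The expected step that the limit leaves unreadable from compound 2 to compound 3 is none beyond the scatter, and compound 3 is expected most likely to return only a limit again.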

Compound 3, dose for 50% inhibition: > 100 umol/kg
Compound 3 gave a limit, no number; the forecaster's own chance of this, stated with the estimate: 75%; the middle value does not contradict the limit.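

No new step can be read in this assay: compound 3 compares with compound 1 and compound 2 only through limits, not numbers. Compound 3 gives > 100 umol/kg, which is a limit of the assay. The compounds shown leave open whether fluoro, nitro and 2-hydroxyethyl on the aromatic carbon differ at all in this assay.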